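The source may hold more compounds than are shown below. What is called first, only, known or untested is meant among the compounds shown, and "the series" means these compounds.

Compound 1 `CC(c1cc(O)nc(SC2CCCC2)n1)c1cccc2ccccc12` and compound 2 `CC(c1cc(O)nc(SC2CCCCC2)n1)c1cccc2ccccc12` share one core and differ in a single group. In a functional assay on MT4 cells (Homo sapiens) for cytotoxicity (on this read-out lower numbers stand for higher toxicity in this test and higher numbers for lower toxicity in this test), compound 1 gives 93000 nM, and in this assay compound 2 gives 45000 nM. The change is cyclohexyl in place of cyclopentyl on a sulfur and it produced the step of a 2.1-fold lower number from compound 1 to compound 2 (0.32 log units; beyond the scatter). Compound 3 `CCC(c1cc(O)nc(SC2CCCC2)n1)c1c(F)cccc1F` carries a different core; how its core differs from that of compound 1 is not broken down here. In this assay compound 3 reaches only the limit of > 200000 nM, a boundary of the test rather than a number, as noted in the limit of > 200000 nM in this assay, at which 1 of the 3 values shown sits. Compound 4 `CCC(c1cc(O)nc(SC2CCCCC2)n1)c1c(F)cccc1F` differs from compound 3 by cyclohexyl in place of cyclopentyl on a sulfur, the same change as before. For compound 4 a step of an at least 1.3-fold lower number from compound 3 to compound 4 (0.12 log units; that floor lies within the scatter) is expected in this assay, resting on the earlier step of a 2.1-fold lower number from compound 1 to compound 2 (0.32 log units; beyond the scatter). Compound 4 is therefore estimated at 150000 nM, between 60000 nM and 400000 nM.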

Compound 4, half-maximal cytotoxic concentration: > 200000 nM
Compound 4 was reported as a limit; the forecaster's own chance of this, stated with the estimate: 50%; at least 1.3-fold (0.12 log units) between middle value and limit.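

The step from compound 3 to compound 4 cannot be read, because both compounds stop at a limit of the test: the limit of > 200000 nM in this assay, at which 2 of the 4 values shown sit.

As far as these compounds go, whether cyclohexyl in place of cyclopentyl on a sulfur lowers the number on the core of compound 3, as it does on the core of compound 1, stays open.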